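The source may hold more compounds than are shown below. What is called first, only, known or untested is meant among the compounds shown, and "the series" means these compounds.

Compound 1 `COc1ncnc2c1c(I)cn2[C@@H]1O[C@H](CO)[C@@H](O)[C@H]1O` sets the weaker end of the pair measured so far: in a functional assay on HL-60 cells (Homo sapiens) for antiproliferative activity, read by XTT assay, with a stated time of 72 h (on this read-out lower numbers stand for stronger inhibition and higher numbers for weaker inhibition), compound 1 gives 2300 nM, the highest of the two numbers, while its nearest neighbour compound 2 `COc1ncnc2c1c(-c1ccsc1)cn2[C@@H]1O[C@H](CO)[C@@H](O)[C@H]1O` gives 130 nM. Going by the values given here, the one step measured between them is an 18-fold lower number from compound 1 to compound 2 (1.25 log units; beyond the scatter), and it concerns the substituent on the five-membered ring of the shared core, not the six-membered ring.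

Compound 3 `Cc1ncnc2c1c(I)cn2[C@@H]1O[C@H](CO)[C@@H](O)[C@H]1O` is the next compound to be measured. Relative to compound 1 the change is methyl in place of methoxy on an aromatic carbon, on an aromatic carbon of a six-membered aromatic ring with two nitrogens, next to the ring nitrogen and ortho to a fused ring. Among the compounds with values here, no measured step touches this position; the only step on record, from iodo to thiophen-3-yl, bears on a different carbon and gives no guide to a methoxy-to-methyl exchange. With nothing in the data pointing in either direction, the expectation for compound 3 in this assay is a step of about a 1.3-fold higher number from compound 1 to compound 3 (0.12 log units; within the scatter), that is, nothing clearly beyond the scatter. Compound 3 is accordingly estimated at 3000 nM, with a range from 800 nM to 12000 nM.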

Compound 3, half-maximal inhibitory concentration: 2650 nM
The estimate for compound 3 lay 1.1-fold (0.05 log units) above the measured number; the range from low to high includes it.
By their numbers in this assay, from the lowest: compound 2; then compounds 1 and 3 (each within the scatter of the next).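

With iodo held in place on the shared core, methyl in place of methoxy on this carbon of the six-membered aromatic ring gives a 1.2-fold higher number from compound 1 to compound 3 (0.06 log units; within the scatter) in this assay, so compound 1 and compound 3 cannot be told apart on this read-out. Going by these compounds alone, this is the first reading at this position, and it shows that the exchange, which takes away one oxygen and one hydrogen-bond acceptor, leaves the number within the scatter in this iodo pair, whereas an 18-fold lower number from compound 1 to compound 2 (1.25 log units; beyond the scatter) stands beyond the scatter for the change at the iodo carbon. No measurement offered here bears on why the methoxy-to-methyl exchange gives this result.

From the compounds shown here alone, whether the same holds with thiophen-3-yl in place of iodo remains open, since the methoxy-to-methyl exchange has been read only with iodo on the core. Also open, going by these compounds, is what an amine, a hydroxyl or a longer alkyl chain on this carbon would give, as methoxy and methyl alone do not show how far this position accepts other groups.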